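A few compounds are considered here, and "the series" means these few. Any claim that something is new, unique, unknown or untested is made for them only; others in the source may bear on it.

Three amides on the shared core have numbers in an ADME assay on PC-3 cells (Homo sapiens) for cytotoxicity, read by WST assay, tested at 100 uM; on this read-out lower numbers stand for less inhibition and higher numbers for more inhibition at the one concentration tested (going by the name of the read-out). Compound 1 `O=C(Nc1ccc(Cl)cc1)C1CCCN(C(=O)c2cccc(-c3nccs3)c2)C1` gives 32%. Compound 2 `O=C(Nc1cccc([N+](=O)[O-])c1)C1CCCN(C(=O)c2cc(C(F)(F)F)cc(C(F)(F)F)c2)C1` gives 9%, and compound 3 `O=C(Nc1cccc(Oc2ccccc2)c1)C1CCCN(C(=O)c2cc(C(F)(F)F)cc(C(F)(F)F)c2)C1` gives 1%. Compound 1 stands highest of the three, with compound 2 nearest and compound 3 furthest, both gaps beyond the scatter. Among the compounds with values here, the only step between measured compounds that differ in one place runs a number 8 percentage points lower from compound 2 to compound 3 (within the scatter), so that exchange on the aryl amide side leaves the read-out essentially where it was.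

Compound 4 `Cc1nc(-c2cccc(C(=O)N3CCCC(C(=O)Nc4ccc(Cl)cc4)C3)c2)cs1` is not yet measured in this assay. It differs from compound 1 in one place: 2-methyl-1,3-thiazol-4-yl in place of 1,3-thiazol-2-yl on an aromatic carbon. Within the data shown here, no measured step alters this part of compound 1; the one step known, between compound 2 and compound 3, touches a different ring and was within the scatter, so the series offers no precedent for a move at the five-membered ring either. The expectation is therefore a step of about a number 2 percentage points lower from compound 1 to compound 4 (within the scatter), which is to say none beyond the scatter, with compound 4 resting near the number of compound 1. Compound 4 is estimated at 30%, with a range from 15% to 45%.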

Compound 4, a percentage reported as inhibition, at one concentration (the size of the read-out at that concentration, not a potency): 1%
Compound 4: the middle estimate sits 29 percentage points above what was measured; measured number outside the range, below it.
By their numbers in this assay, from the lowest: compounds 3, 4 and 2 (each within the scatter of the next); then compound 1.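

In this assay, within the data shown here, exchanging 1,3-thiazol-2-yl for 2-methyl-1,3-thiazol-4-yl on an aromatic carbon of a six-membered aromatic ring of carbon only, meta to a large group, gives a number 31 percentage points lower from compound 1 to compound 4 (beyond the scatter), so the read-out at this place responds strongly to a change in the five-membered ring, something the only earlier step, at a different ring, gave no sign of. The counts for the two groups match in ring type, hetero atoms, hydrogen-bond donors, hydrogen-bond acceptors and net charge, so a large step arises here with those counts unchanged, while the exchange alters both the point of attachment of the ring and the presence of a methyl group. The data shown hold no evidence that accounts for this step.

The compounds shown leave open whether the attachment point or the methyl group carries the step, a question that the unsubstituted 1,3-thiazol-4-yl or the 2-methyl-1,3-thiazol-5-yl group would bear on. They also leave open how this place responds to groups of another kind, such as an amine or a carboxylic acid on the five-membered ring.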